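The source may hold more compounds than are shown below. What is called first, only, known or untested is meant among the compounds shown, and "the series" means these compounds.

For the measured compounds named here, compound 2 `C=CCCCCC(=O)O[C@H](CC=C(C)C)C1=CC(=O)c2c(O)ccc(O)c2C1=O` gives 250000 nM in an assay on HeLa cells for inhibition of DNA topoisomerase 1 (Homo sapiens) (a lower number here means a stronger inhibitor, a higher number a weaker inhibitor), the highest of the two numbers so far; compound 1 `CC(C)=CC[C@@H](OC(=O)C(Cl)(Cl)Cl)C1=CC(=O)c2c(O)ccc(O)c2C1=O` gives 115000 nM in this assay. Going by the values given here, the only measured step, a 2.2-fold higher number from compound 1 to compound 2 (0.34 log units; beyond the scatter), concerns a different exchange on the same carbonyl carbon. Compound 3 `CC(C)=CC[C@@H](OC(=O)C=C(C)C)C1=CC(=O)c2c(O)ccc(O)c2C1=O` carries 2-methylprop-1-en-1-yl in place of hex-5-en-1-yl on a carbonyl carbon. Among the compounds with values here, no measured step matches this change, so its size is open; the one known exchange at this carbon was modest, and for compound 3 a similarly modest move, direction uncertain, is expected: a 1.7-fold lower number from compound 2 to compound 3 (0.22 log units; within the scatter). For compound 3 the expected value in this assay is 150000 nM, estimated to lie between 60000 nM and 400000 nM.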

Compound 3, half-maximal inhibitory concentration: 77000 nM
Estimate against measurement, compound 3: 1.9-fold (0.29 log units) above; the range from low to high includes it.
By their numbers in this assay, from the lowest: compounds 3 and 1 (each within the scatter of the next); then compound 2.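

Exchanging hex-5-en-1-yl for 2-methylprop-1-en-1-yl on this carbonyl carbon gives a 3.2-fold lower number from compound 2 to compound 3 (0.51 log units; beyond the scatter) in this assay, so hex-5-en-1-yl now stands apart from two different groups at this position. Against trichloromethyl, the same group gives a 1.5-fold lower number from compound 1 to compound 3 (0.17 log units; within the scatter), so these two groups cannot be told apart here. Nothing at hand accounts for these numbers.

Still open, going by these compounds, is whether a longer chain or a saturated one behaves like hex-5-en-1-yl. Also open, on these data alone, is whether an amine or a carboxylic acid on this carbonyl carbon would separate from compound 1 and compound 3.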